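Swapping the aryl group on the amide-type nitrogen

This account rests on a few compounds, and the source may have more. Where it says the series, first, only, none or still open, it means among the compounds named here.

Measured compounds:
Compound 1 `CCOc1ccc(NC(=O)Nc2cccc(CNc3nccnc3Cl)c2)cc1`: 9080 nM
Compound 2 `COc1ccccc1NC(=O)Nc1cccc(CNc2nccnc2Cl)c1`: 10400 nM

In a functional assay on T-24 cells (Homo sapiens) for antiproliferative activity, read by MTT assay, with a stated time of 48 h (a lower number here means a stronger inhibitor, a higher number a weaker inhibitor), compound 1 has the smaller of the two numbers, yet the gap to compound 2 is within the scatter, so neither stands apart. Among the measured compounds shown here, the one measured step, a 1.1-fold higher number from compound 1 to compound 2 (0.06 log units; within the scatter), shows that exchanging the aryl group on this nitrogen changed little. Compound 3 `O=C(Nc1cccc(CNc2nccnc2Cl)c1)Nc1ccc(Cl)cc1Cl` differs from compound 1 by 2,4-dichlorophenyl in place of 4-ethoxyphenyl on an amide-type nitrogen. For the measured compounds named here, no measured step involves a 2,4-dichlorophenyl, so the expectation rests only on that single, small aryl swap. The expected step, a 1.3-fold lower number from compound 1 to compound 3 (0.11 log units; within the scatter), is modest. Compound 3 is estimated at 7000 nM, with a range from 2500 nM to 20000 nM.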

Compound 3, half-maximal inhibitory concentration: 5740 nM
Beside the measured number, compound 3's estimate is 1.2-fold (0.09 log units) above it, within the range that was stated.
By their numbers in this assay, from the lowest: compounds 3, 1 and 2 (each within the scatter of the next).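

In this assay, the step of a 1.6-fold lower number from compound 1 to compound 3 (0.20 log units; within the scatter) and the step of a 1.8-fold lower number from compound 2 to compound 3 (0.26 log units; within the scatter) show that this amide-type nitrogen also accepts 2,4-dichlorophenyl, an aryl group with chlorine rather than an oxygen-linked chain, without leaving the scatter. Across the 4-ethoxyphenyl, 2-methoxyphenyl and 2,4-dichlorophenyl groups of compound 1, compound 2 and compound 3, the numbers therefore stay within the scatter of one another. No supporting evidence bears on this result. On these data alone, whether an aryl group carrying a carboxylic acid or an amine, or a longer chain in place of the aryl group, would move the number beyond the scatter remains open.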